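Swapping the amide aryl group on the core of compound 1

The compounds below may be only part of what the source reports. "The series", "measured", "known", "first", "only" and "open" are said of these compounds alone.

Measured compounds:
Compound 1, `O=C(COc1c(-c2ccccc2)oc2ccccc2c1=O)Nc1ccc2ccccc2c1`: 6520 nM
Compound 2, `O=C(COc1ccc2c(=O)cc(-c3ccccc3)oc2c1)Nc1ccc2ccccc2c1`: > 10000 nM (a limit)

Among the measured compounds shown here, in a functional assay on NPC-TW01 cells (Homo sapiens) for antiproliferative activity, read by MTT assay, with a stated time of 72 h (on this read-out lower numbers stand for stronger inhibition of growth and higher numbers for weaker inhibition of growth), compound 1 gives 6520 nM, the only numeric value among the two measured compounds. For compound 2 this assay returns only a limit, > 10000 nM. Compound 3, `COc1ccc(NC(=O)COc2c(-c3ccccc3)oc3ccccc3c2=O)cc1`, differs from compound 1 by 4-methoxyphenyl in place of naphthalen-2-yl on an amide-type nitrogen. For the measured compounds named here, no measured pair isolates this change, so its size is open; the step is expected to be modest and toward weaker inhibition, possibly not beyond the scatter, giving an expected 1.4-fold higher number from compound 1 to compound 3 (0.14 log units; within the scatter). Compound 3 is therefore estimated at 9000 nM, in the range 3500 nM to 25000 nM.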

Compound 3, concentration for 50% growth inhibition: 5480 nM
For compound 3 the middle estimate is 1.6-fold (0.22 log units) above the measured one; low and high end bracket the measured number.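

In this assay, replacing naphthalen-2-yl with 4-methoxyphenyl on the amide-type nitrogen gives a 1.2-fold lower number from compound 1 to compound 3 (0.08 log units; within the scatter) and so leaves growth inhibition unchanged within the usual scatter. At this position, on this core, one six-membered aromatic ring with a methoxy group therefore does as well as the two rings of naphthalen-2-yl. From the compounds shown here alone, whether an amine, a carboxylic acid or a longer chain on this nitrogen would move the number beyond the scatter remains open. Compound 2 offers no number for comparison, only a limit: the limit of > 10000 nM in this assay, at which 1 of the 3 values shown sits.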